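Methylsulfanyl for chloro on a triazole-linked phenyl ring

A few compounds are considered here, and "the series" means these few. Any claim that something is new, unique, unknown or untested is made for them only; others in the source may bear on it.

Compound 1 `COc1cc(-c2ncnn2-c2cccc(F)c2)cc(OC)c1OC` in a functional assay on A549 cells (Homo sapiens) for antiproliferative activity, read by MTT assay, with a stated time of 72 h (on this read-out higher numbers stand for weaker inhibition and lower numbers for stronger inhibition), gives > 10000 nM, a limit of the assay.
Compound 2 `COc1cc(-n2ncnc2-c2ccc(Cl)cc2)cc(OC)c1OC` in this assay gives > 10000 nM, again a limit.
Compound 3 `COc1cc(-c2ncnn2-c2ccc(N)cc2)cc(OC)c1OC` in this assay gives > 10000 nM, also a limit.

Compound 2 stands where every measured compound stands: at a limit of this assay, not at a number, because of the limit of > 10000 nM in this assay, at which 3 of the 3 values shown sit. Among the measured compounds shown here, the step that the two limits leave unreadable from compound 1 to compound 3 is the only one between measured compounds that differ in one place, and the two limits leave it unreadable. Compound 4 `COc1cc(-n2ncnc2-c2ccc(SC)cc2)cc(OC)c1OC` arises from compound 2 by methylsulfanyl in place of chloro on an aromatic carbon. For the measured compounds named here, no measured step bears on this change, since all values shown are limits. With nothing pointing to a readable gain, compound 4 is expected to remain near a limit as well, so the step that the limit leaves unreadable from compound 2 to compound 4 in this assay is expected to be small or none beyond the scatter. Compound 4 is therefore estimated at 15000 nM, within 3000 nM to 80000 nM, with the assay most likely reporting only a limit.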

Compound 4, half-maximal inhibitory concentration: 800 nM
For compound 4 the middle estimate is 19-fold (1.27 log units) above the measured one, outside the stated range (below it).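

In this assay, methylsulfanyl in place of chloro gives an at least 12-fold lower number from compound 2 to compound 4 (1.09 log units; beyond the scatter), the first step among the compounds shown that can be read at all. It shows that the group on this aromatic carbon, para to a large group, matters on this core: exchanging chloro for methylsulfanyl is enough to bring compound 4 to a measured number. Compound 2 itself stands at a limit, so the step fixes only a floor for the size of this change, and its full size stays unknown: the limit of > 10000 nM in this assay, at which 3 of the 4 values shown sit.

As far as these compounds go, whether the gain needs the sulfur atom stays open, since a methoxy, an ethylsulfanyl or a methylsulfonyl group at this place could behave differently. Also open, from the compounds shown here alone, is whether methylsulfanyl would do the same on the differently joined core of compound 1.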